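The compounds below may be only part of what the source reports. "The series", "measured", "known", "first", "only" and "open" are said of these compounds alone.

Working notes on the series in an ADME assay on HUVEC cells (Homo sapiens) for antiproliferative activity, read by MTT assay, with a stated time of 48 h; a higher number here means a weaker inhibitor, a lower number a stronger inhibitor.

Compound 1 `CCOc1ccc(-n2nncc2CN2C(=O)C3(C(C#N)=C(N)Oc4c(N)cc5nc6ccccc6nc5c43)c3ccccc32)cc1` carries a 4-ethoxyphenyl on the ring nitrogen. In this assay compound 1 gives only a limit of the assay, > 50000 nM. Compound 2 `N#CC1=C(N)Oc2c(N)cc3nc4ccccc4nc3c2C12C(=O)N(Cc1cnnn1-c1ccc([N+](=O)[O-])cc1)c1ccccc12` replaces the ethoxy with nitro. In this assay compound 2 likewise returns a limit, > 50000 nM. Compound 3 `N#CC1=C(N)Oc2c(N)cc3nc4ccccc4nc3c2C12C(=O)N(Cc1cnnn1-c1c(F)cccc1F)c1ccccc12` carries a 2,6-difluorophenyl instead. In this assay compound 3 also sits at a limit, > 50000 nM. Every value shown so far is therefore a limit, (the limit of > 50000 nM in this assay, at which 3 of the 3 values shown sit), and none of the steps can be sized: a step that the two limits leave unreadable from compound 1 to compound 2, a step that the two limits leave unreadable from compound 1 to compound 3, a step that the two limits leave unreadable from compound 2 to compound 3.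

Compound 4 `Cc1ccc(-n2nncc2CN2C(=O)C3(C(C#N)=C(N)Oc4c(N)cc5nc6ccccc6nc5c43)c3ccccc32)cc1Cl` is not yet measured. The change from compound 3 is 3-chloro-4-methylphenyl in place of 2,6-difluorophenyl on an aromatic nitrogen. Among the measured compounds shown here, the steps that bear on it are the three aryl exchanges on the same ring nitrogen just named; all of them stay at the limit and give no readable size. Nothing in the measured data therefore points to any shift in this assay beyond the scatter, in either direction. The expectation is that compound 4 will again return a limit rather than a number, with an estimated value of 70000 nM spanning 20000 nM to 250000 nM. The step this estimate implies, a step that the limit leaves unreadable from compound 3 to compound 4, is expected to be unreadable as before.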

Compound 4, half-maximal inhibitory concentration: > 50000 nM
Compound 4: no number, only a limit; the forecaster's own chance of this, stated with the estimate: 85%; the middle value lies beyond the limit too.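

In this assay compound 4 gives > 50000 nM, again a limit and not a number, so none of its steps from compound 1, compound 2 or compound 3 can be read: the limit of > 50000 nM in this assay, at which 4 of the 4 values shown sit.

The compounds shown leave open whether any of these aryl exchanges on the ring nitrogen shifts the half-maximal inhibitory concentration in this assay at all, and by how much.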